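The source may report more compounds than this note shows. Statements on the series, on what has been measured and on what is new or still open speak of the compounds shown alone.

Measured compounds:
Compound 1, `Brc1cn2ccnc2c(-c2ccc3ncn(C4CCCCC4)c3c2)n1`, in a functional assay on IGROV-1 cells (Homo sapiens) for inhibition, read by sulforhodamine B assay, with a stated time of 48 h, tested at 10 uM (a higher number here means more inhibition at the concentration tested (going by the name of the read-out), a lower number less inhibition), gives 6.6%.
Compound 2, `c1ccc(-c2cn3ccnc3c(-c3ccc4ncn(C5CCCCC5)c4c3)n2)cc1`, in this assay gives 12%.

Going by the values given here, compound 2 holds the highest of the two numbers, yet its gap to compound 1 is within the scatter; the only measured step, a number 5.4 percentage points higher from compound 1 to compound 2 (within the scatter), is likewise within the scatter. Compound 3, `COc1ccc(-c2cn3ccnc3c(-c3ccc4ncn(C5CCCCC5)c4c3)n2)cc1`, differs from compound 2 by methoxy in place of hydrogen on an aromatic carbon. Among the compounds with values here, no measured step exchanges hydrogen for methoxy, so none bears directly on this change. A step beyond the scatter is therefore not expected. Compound 3 is estimated at 14%, between 0% and 35%. The expected step is a number 2 percentage points higher from compound 2 to compound 3 (within the scatter).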

Compound 3, a percentage reported as inhibition, at one concentration (the size of the read-out at that concentration, not a potency): 53.4%
Beside the measured number, compound 3's estimate is 39.4 percentage points below it; measured number above the stated range.
By their numbers in this assay, from the lowest: compounds 1 and 2 (each within the scatter of the next); then compound 3.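

In this assay, going by these compounds alone, methoxy in place of hydrogen, para to a large group on a six-membered aromatic ring, brings a number 41.4 percentage points higher from compound 2 to compound 3 (beyond the scatter) and is the first change here to pass the scatter. The exchange of bromo for 4-methoxyphenyl likewise gives a number 46.8 percentage points higher from compound 1 to compound 3 (beyond the scatter) while phenyl in place of bromo stayed within the scatter, so among these compounds the large gain appears only with methoxy present. Nothing measured here accounts for this rise.

On these data alone, it remains open whether a hydroxyl, an ethoxy or an amine in that place would give a similar number. As far as these compounds go, it is also open whether methoxy elsewhere on that ring would do so.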